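This account rests on a few compounds, and the source may have more. Where it says the series, first, only, none or still open, it means among the compounds named here.

Measured compounds:
Compound 1 `C(#Cc1nc2c(s1)CN(C1CCCCC1)CC2)c1ccccc1` — in an assay on HEK293 cells for positive allosteric modulation of metabotropic glutamate receptor 5 (Homo sapiens), read by FLIPR, with a stated time of 1 h (on this read-out higher numbers stand for an effect only at larger amounts of compound and lower numbers for an effect already at smaller amounts), compound 1 gives > 10000 nM, which is a limit of the assay and not a number.
Compound 2 `O=C(C1CC1)N1CCc2nc(C#Cc3ccccc3)sc2C1` — in this assay compound 2 gives > 10000 nM, likewise only a limit.

Compound 2 thus stands at the limit, as does compound 1; the step that the two limits leave unreadable from compound 1 to compound 2 cannot be read, since both values sit at the limit of > 10000 nM in this assay, at which 2 of the 2 values shown sit. Compound 3 `O=C(C1CCCC1)N1CCc2nc(C#Cc3ccccc3)sc2C1` differs from compound 2 by cyclopentyl in place of cyclopropyl on a carbonyl carbon. For the measured compounds named here, no measured step bears on this change; the only available comparison is unreadable. Compound 3 is therefore expected to remain near or beyond the limit, an estimated step that the limit leaves unreadable from compound 2 to compound 3. The estimate for compound 3 in this assay is 15000 nM, with a range from 4000 nM to 60000 nM.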

Compound 3, half-maximal effective concentration: 19 nM
Compound 3: the middle estimate sits 790-fold (2.90 log units) above what was measured, outside the stated range (below it).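

In this assay, the group on the carbonyl carbon proves able to carry the series from the limit to a readable value: cyclopentyl in place of cyclopropyl gives an at least 520-fold lower number from compound 2 to compound 3 (2.72 log units; beyond the scatter). Cyclopentylcarbonyl in place of cyclohexyl on an amine nitrogen in a ring gives an at least 520-fold lower number from compound 1 to compound 3 (2.72 log units; beyond the scatter). Only compound 3 has left the limit, so both steps give a minimum size and not an exact one: the limit of > 10000 nM in this assay, at which 2 of the 3 values shown sit.

Open, as far as these compounds go, is whether cyclobutyl or cyclohexyl on the carbonyl carbon keeps a readable value. The same holds for an open chain such as isopropyl or for a phenyl ring there.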